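A few compounds are considered here, and "the series" means these few. Any claim that something is new, unique, unknown or untested is made for them only; others in the source may bear on it.

Two close relatives have been measured so far. Compound 1 `C=CCOc1ccc(C(=O)Nc2cccc(C)n2)cc1` carries a methyl group on its six-membered aromatic ring with one nitrogen, and in an in vitro assay on HEK-tsA201 cells for antagonist activity at Neuronal acetylcholine receptor; alpha3/beta4 (Homo sapiens), read by fluorescence and calcium flux (a lower number here means a stronger inhibitor, a higher number a weaker inhibitor), compound 1 gives 31700 nM. Compound 2 `C=CCOc1ccc(C(=O)Nc2cccc(CC)n2)cc1` differs only in having an ethyl group at that spot, and in this assay compound 2 gives 27400 nM. For the measured compounds named here, the single step between them, a 1.2-fold lower number from compound 1 to compound 2 (0.06 log units; within the scatter), is too small to count as a real change, so the two compounds are best regarded as equally weak. On the numbers shown, compound 2 has the lowest value of the two, but nothing separates it from compound 1 beyond the scatter.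

Compound 3 `C=CCOc1ccc(C(=O)Nc2cccc(NCCCC)n2)cc1` goes further: butylamino in place of ethyl on an aromatic carbon. Going by the values given here, the only measured step, the methyl-to-ethyl extension, bears on this only loosely, since it lengthened the chain without adding the hydrogen-bond donor and acceptor that the butylamino group brings. Among the compounds with values here, no measured step tells how such a group behaves here, so only a modest shift is expected. The estimate for compound 3 in this assay is 20000 nM, with a range from 6000 nM to 60000 nM, which means an expected step of a 1.4-fold lower number from compound 2 to compound 3 (0.14 log units; within the scatter).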

Compound 3, half-maximal inhibitory concentration: 19200 nM
For compound 3 the middle estimate is 1.0-fold (0.02 log units) above the measured one; measured number inside the range.
By their numbers in this assay, from the lowest: compounds 3, 2 and 1 (each within the scatter of the next).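

Until now, this position, on an aromatic carbon next to the ring nitrogen, had been probed only with methyl and ethyl, two plain carbon groups. Compound 3 shows that butylamino, a longer group that brings a hydrogen-bond donor and a hydrogen-bond acceptor, can stand at the same spot with no real shift in this assay: the result is a 1.4-fold lower number from compound 2 to compound 3 (0.15 log units; within the scatter), and against the methyl group it is a 1.7-fold lower number from compound 1 to compound 3 (0.22 log units; within the scatter), so methyl, ethyl and butylamino cannot be told apart here. No measurement shown accounts for this flat result.

Butylamino differs from ethyl in both its length and its nitrogen, so the effects of these two features remain unseparated; a plain butyl chain and a short methylamino group would pull them apart. From the compounds shown here alone, it also remains open whether a much different group at this position, such as a carboxylic acid, or a change elsewhere on the core would give a step beyond the scatter.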